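The source may hold more compounds than are shown below. What is called first, only, known or untested is meant among the compounds shown, and "the series" means these compounds.

In a functional assay on SK-OV-3 cells (Homo sapiens) for cytotoxicity, read by spectrophotometry, with a stated time of 72 h (a lower number here means a stronger inhibitor, a higher number a weaker inhibitor), three compounds that share one core have been measured so far. Compound 1 `COc1cc(-n2c(-c3ccc([N+](=O)[O-])cc3)cccc2=O)cc(OC)c1OC`, which carries a 4-nitrophenyl group, gives 201 nM, the lowest number of the three. Compound 3 `COc1cc(-n2c(-c3ccc(OC(F)(F)F)cc3)cccc2=O)cc(OC)c1OC` gives 461 nM, and compound 2 `COc1cc(-n2c(-c3ccncc3)cccc2=O)cc(OC)c1OC` gives 1790 nM.

The unmeasured compound 4 `COc1cc(-n2c(-c3cccc4cc[nH]c34)cccc2=O)cc(OC)c1OC` changes the same place on the core: 1H-indol-7-yl in place of 4-nitrophenyl on an aromatic carbon. In plain terms, 1H-indol-7-yl stands in place of 4-nitrophenyl on an aromatic carbon, next to the ring nitrogen.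

Among the measured compounds shown here, two measured steps bear on this change. Trifluoromethoxy in place of nitro gave a 2.3-fold higher number from compound 1 to compound 3 (0.36 log units; beyond the scatter), and pyridin-4-yl in place of 4-nitrophenyl gave an 8.9-fold higher number from compound 1 to compound 2 (0.95 log units; beyond the scatter). Both steps are modest, and both raised the number. Neither brings in a five-membered aromatic ring or a hydrogen-bond donor, so they offer only an indirect guide to the new group. A modest step towards a higher number is therefore the likeliest outcome, although a lower number cannot be ruled out. The expected change is a 2.0-fold higher number from compound 1 to compound 4 (0.30 log units; within the scatter). The estimate for compound 4 is 400 nM, with an expected range from 70 nM to 2000 nM.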

Compound 4, half-maximal inhibitory concentration: 138 nM
Compound 4: the middle estimate sits 2.9-fold (0.46 log units) above what was measured; the measured number falls inside the stated range.
By their numbers in this assay, from the lowest: compounds 4 and 1 (each within the scatter of the next); then compound 3; then compound 2.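

In this assay the change shows up as a 1.5-fold lower number from compound 1 to compound 4 (0.16 log units; within the scatter) and so leaves the two compounds within the scatter of each other, which means that a group with a five-membered aromatic ring and a hydrogen-bond donor can stand at this place on the core without losing ground to 4-nitrophenyl. The same group compared with pyridin-4-yl gives a 13-fold lower number from compound 2 to compound 4 (1.11 log units; beyond the scatter) and this large step shows how much the choice of aromatic group at this one place can matter. Since 4-nitrophenyl and 1H-indol-7-yl have no hydrogen-bond acceptor count or donor count in common, a nitro group is not needed for a number at this level, at least among these compounds.

Nothing shown here gives a measured reason for these numbers. Also open, on these data alone, is whether the hydrogen on the indole nitrogen plays any part, which 1-methyl-1H-indol-7-yl could test, and whether the attachment point matters, which 1H-indol-5-yl could test, while a phenyl ring bearing an amine or a carboxylic acid would probe quite different groups at this place.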